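Aryl swap on the piperazine of a urea series

This account rests on a few compounds, and the source may have more. Where it says the series, first, only, none or still open, it means among the compounds named here.

Three compounds share one core and differ only in the aryl group on the ring nitrogen. Compound 1 `CCOc1ccccc1N1CCN(CCCNC(=O)N2C(=O)NC(C)=C(C(=O)OC)C2c2ccc(F)c(F)c2)CC1` gives 14 nM in an assay on liver for binding affinity to Alpha-1D adrenergic receptor (Homo sapiens), using microsomes (on this read-out lower numbers stand for stronger inhibition and higher numbers for weaker inhibition), compound 2 `COC(=O)C1=C(C)NC(=O)N(C(=O)NCCCN2CCN(c3cccc(Cl)c3)CC2)C1c1ccc(F)c(F)c1` gives 37 nM, and compound 3 `COC(=O)C1=C(C)NC(=O)N(C(=O)NCCCN2CCN(c3cccc([N+](=O)[O-])c3)CC2)C1c1ccc(F)c(F)c1` gives 340 nM, the highest of the three. The step to compound 4 `COC(=O)C1=C(C)NC(=O)N(C(=O)NCCCN2CCN(c3ccccc3Cl)CC2)C1c1ccc(F)c(F)c1` is 2-chlorophenyl in place of 3-nitrophenyl on an amine nitrogen in a ring. The nearest measured step runs the other way: a 9.2-fold higher number from compound 2 to compound 3 (0.96 log units; beyond the scatter). The larger step of a 24-fold higher number from compound 1 to compound 3 (1.39 log units; beyond the scatter) also points down from compound 3, and a 2.6-fold higher number from compound 1 to compound 2 (0.42 log units; beyond the scatter) shows the 2-substituted aryl in compound 1 ahead of the 3-substituted one in compound 2. Compound 4 is therefore expected to show a 15-fold lower number from compound 3 to compound 4 (1.19 log units; beyond the scatter), landing at an estimated 22 nM with a range of 7 nM to 70 nM.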

Compound 4, inhibition constant: 14 nM
For compound 4 the middle estimate is 1.6-fold (0.20 log units) above the measured one; measured number inside the range.
By their numbers in this assay, from the lowest: compounds 1 and 4 (each within the scatter of the next); then compound 2; then compound 3.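

In this assay, keeping the chloro and changing only 3-chlorophenyl to 2-chlorophenyl gives a 2.6-fold lower number from compound 2 to compound 4 (0.42 log units; beyond the scatter), so the place of the same group on the aryl ring matters by itself. Chloro in place of ethoxy gives no change at the digits printed from compound 1 to compound 4 (within the scatter), so these two 2-substituted aryl groups do not separate here. The full swap gives a 24-fold lower number from compound 3 to compound 4 (1.39 log units; beyond the scatter), which matches the largest step seen so far in this short series.

Nothing shown explains these differences. Going by these compounds, whether a methoxy group in place of the chloro of compound 4 would stay level with compound 1 remains open.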